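Moving a Fluorine: From Compound 3 Toward Compound 4

The source may report more compounds than this note shows. Statements on the series, on what has been measured and on what is new or still open speak of the compounds shown alone.

Compound 2 `O[C@H](COc1ccc(C(F)(F)F)cc1)CN1CCN(c2ccc(F)cc2)CC1` and compound 1 `O[C@H](COc1ccc(C(F)(F)F)cc1)CN1CCN(c2ccccc2F)CC1` share one core, while compound 3 `O[C@@H](COc1ccc(Cl)cc1)CN1CCN(c2ccc(F)cc2)CC1` and the unmeasured compound 4 `O[C@@H](COc1ccc(Cl)cc1)CN1CCN(c2ccccc2F)CC1` share another, and the difference between the two cores is not broken down here. In an assay on HEK293 cells for inhibition of Voltage-dependent T-type calcium channel subunit alpha-1G (Homo sapiens), read by patch clamp, tested at 10 uM (a higher number here means more inhibition at the concentration tested (going by the name of the read-out), a lower number less inhibition), compound 2 gives 59.2%, and compound 1 gives 48.9%. The change between them, (2-fluorophenyl in place of 4-fluorophenyl on an amine nitrogen in a ring), made a step of a number 10.3 percentage points lower from compound 2 to compound 1 (beyond the scatter). In this assay compound 3 gives 39.7%. Compound 4 carries the same change on the other core: 2-fluorophenyl in place of 4-fluorophenyl on an amine nitrogen in a ring. Because the earlier step was a number 10.3 percentage points lower from compound 2 to compound 1 (beyond the scatter), a similar drop is expected, so the step from compound 3 to compound 4 is estimated as a number 9.7 percentage points lower from compound 3 to compound 4 (within the scatter). Among the compounds with values here, compound 4 is therefore expected to show about 30% in this assay, plausibly between 15% and 45%, a wide range since only one earlier example of this change exists.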

Compound 4, a percentage reported as inhibition, at one concentration (the size of the read-out at that concentration, not a potency): 46.9%
Beside the measured number, compound 4's estimate is 16.9 percentage points below it; the whole stated range lies below it.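

With 2-fluorophenyl in place of 4-fluorophenyl, this assay shows a number 7.2 percentage points higher from compound 3 to compound 4 (within the scatter), so the drop seen on the first core did not carry over to the second. The change therefore cannot be assumed to act alike on these two cores: the same change on two cores in this assay, a number 10.3 percentage points lower (beyond the scatter) from compound 2 to compound 1 and a number 7.2 percentage points higher (within the scatter) from compound 3 to compound 4, 17.5 percentage points apart, beyond the scatter of two such steps. This rests on a single pair of compounds per core, and it does not show which part of the difference between the cores is responsible, or what the change would do on a third core.

The compounds shown leave open how the two cores would respond if the fluorine on the phenyl ring gave way to another group, such as a methoxy group or a nitrile. They also leave open whether a longer chain between the piperazine-like ring and the oxygen would alter the outcome.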